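The source may report more compounds than this note shows. Statements on the series, on what has been measured and on what is new or still open speak of the compounds shown alone.

In a functional assay on HepG2 cells (Homo sapiens) for cytotoxicity, read by MTT assay, with a stated time of 24 h (a lower number here means a stronger inhibitor, a higher number a weaker inhibitor), compound 1 (`CN1C/C(=C\c2ccncc2)C(=O)/C(=C/c2ccccc2C(F)(F)F)C1`) gives 3300 nM, compound 2 (`O=C1/C(=C/c2cccnc2)CNC/C1=C\c1ccccc1C(F)(F)F`) gives 5020 nM and compound 3 (`Cc1ccc(S(=O)(=O)N2C/C(=C\c3cccnc3)C(=O)/C(=C/c3ccccc3C(F)(F)F)C2)cc1`) gives 2930 nM. These three numbers lie within the scatter of one another, so compound 3 stands level with both of the others. Compound 4 (`Cc1ccc(S(=O)(=O)N2C/C(=C\c3ccncc3)C(=O)/C(=C/c3ccccc3C(F)(F)F)C2)cc1`) remains unmeasured. Its change from compound 3 is pyridin-4-yl in place of pyridin-3-yl on a double-bonded chain carbon bound to a double-bonded ring carbon, on a double-bonded chain carbon bound to a double-bonded ring carbon.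

Among the measured compounds shown here, no measured step isolates this exchange. For the measured compounds named here, the only single-place step, a 1.7-fold lower number from compound 2 to compound 3 (0.23 log units; within the scatter), concerns the amine nitrogen in a ring and stays within the scatter. Going by the values given here, compound 1 carries pyridin-4-yl and gives 3300 nM, but its group on that nitrogen also differs from the one in compound 3. No step beyond the scatter is therefore expected in this assay, and no direction can be assigned. The estimate means a 1.0-fold higher number from compound 3 to compound 4 (0.01 log units; within the scatter), which is expected to stay inside the scatter. Compound 4 is estimated at 3000 nM, with an expected range of 1500 nM to 6000 nM.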

Compound 4, half-maximal inhibitory concentration: 4640 nM
Estimate against measurement, compound 4: 1.5-fold (0.19 log units) below; the measured number falls inside the stated range.
By their numbers in this assay, from the lowest: compounds 3, 1, 4 and 2 (each within the scatter of the next).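

In this assay, among the compounds shown here, the step of a 1.6-fold higher number from compound 3 to compound 4 (0.20 log units; within the scatter) gives the first direct reading of this exchange, and it does not separate pyridin-4-yl from pyridin-3-yl on a double-bonded chain carbon bound to a double-bonded ring carbon. With pyridin-4-yl held constant, the step of a 1.4-fold higher number from compound 1 to compound 4 (0.15 log units; within the scatter) also leaves (4-methylphenyl)sulfonyl and methyl on the amine nitrogen in a ring unseparated, so neither place yet shows a measurable dependence on the group it carries. No supporting measurement bears on these results.

From the compounds shown here alone, whether a plain phenyl or a pyridin-2-yl at the chain carbon would give a step beyond the scatter remains open. The same holds for an acetyl group or a longer alkyl chain on the ring nitrogen.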